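Same Sulfur Change, Second Core, Expected Weaker Blocker

This account rests on a few compounds, and the source may have more. Where it says the series, first, only, none or still open, it means among the compounds named here.

Compound 1 `CSc1ccccc1Nc1nc2c(Nc3ccc(C(F)(F)F)cc3)ncnc2s1` and compound 2 `CS(=O)(=O)c1ccccc1Nc1nc2c(Nc3ccc(C(F)(F)F)cc3)ncnc2s1` share one core. In a functional assay on HEK293 cells for antagonist activity at transient receptor potential cation channel subfamily V member 1 (Rattus norvegicus), read by calcium flux (a higher number here means a weaker inhibitor, a lower number a stronger inhibitor), compound 1 gives 26 nM, and compound 2 gives 221 nM. The change is methylsulfonyl in place of methylsulfanyl on an aromatic carbon, and it made an 8.5-fold higher number from compound 1 to compound 2 (0.93 log units; beyond the scatter). Compound 3 `CSc1nc(Nc2ccc(C(F)(F)F)c(Cl)c2)c2nc(Nc3c(Cl)cccc3Cl)sc2n1` rests on a different core; the difference between the two cores is not broken down here. In this assay compound 3 gives 113 nM. Compound 4 `CS(=O)(=O)c1nc(Nc2ccc(C(F)(F)F)c(Cl)c2)c2nc(Nc3c(Cl)cccc3Cl)sc2n1` is not yet measured and differs from compound 3 by methylsulfonyl in place of methylsulfanyl on an aromatic carbon. This is the same kind of change, not the same: in compound 1 the group sits on a six-membered aromatic ring of carbon only, ortho to a large group, whereas in compound 3 it sits on a six-membered aromatic ring with two nitrogen, between two ring nitrogen atoms, meta and para to a fused ring. For compound 4 a weakening is expected, a 4.4-fold higher number from compound 3 to compound 4 (0.65 log units; beyond the scatter), somewhat smaller and less certain because an 8.5-fold higher number from compound 1 to compound 2 (0.93 log units; beyond the scatter) was measured in different surroundings. Compound 4 is estimated at 500 nM, from 150 nM to 1800 nM.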

Compound 4, half-maximal inhibitory concentration: 77 nM
Compound 4: middle estimate off by 6.5-fold (0.81 log units), on the high side, outside the stated range (below it).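

On the core of compound 3, the swap from methylsulfanyl to methylsulfonyl gave a 1.5-fold lower number from compound 3 to compound 4 (0.17 log units; within the scatter), so the two compounds cannot be told apart in this assay. The clear weakening seen on the core of compound 1 did not carry over, and the two steps differ: the same change on two cores in this assay, an 8.5-fold higher number (0.93 log units; beyond the scatter) from compound 1 to compound 2 and a 1.5-fold lower number (0.17 log units; within the scatter) from compound 3 to compound 4, 12-fold (1.10 log units) apart, beyond the scatter of two such steps So in these two pairs the outcome of this change depends on the core, but the pairs do not show which feature of the cores matters, and two pairs make no general rule.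

The compounds shown leave open how other groups at this place, such as an amine or a longer chain on the sulfur, would behave on either core. They also leave open whether any such group would track the core in the same way.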